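Ring Contraction at the Aromatic Nitrogen: Stability Notes

This account rests on a few compounds, and the source may have more. Where it says the series, first, only, none or still open, it means among the compounds named here.

Two members of the series carry a number in an ADME assay on microsomes from liver (Mus musculus) for metabolic stability, read by LC-MS, using NADPH, with a stated time of 10 min, tested at 10 uM (a higher number here means that the compound lasts longer, a lower number that the compound disappears faster), so far. Compound 1 `Nc1ncnc2c1c(Oc1cc(Cl)ccn1)nn2C1CCC1` gives 0.0617 h in this assay, the lower of the two numbers shown. Compound 2 `Nc1ncnc2c1c(Oc1cc(C(F)(F)F)ccn1)nn2[C@H]1C[C@H](F)C1` gives 0.883 h in this assay, and the gap between those two values lies beyond the scatter, so compound 1 is clearly the shorter-lived of the pair. Among the measured compounds shown here, no step between compounds differing in a single place is available to lean on.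

Compound 3 `Nc1ncnc2c1c(Oc1cc(Cl)ccn1)nn2C1CC1` is the next one to be run in this assay. Its change from compound 1 is cyclopropyl in place of cyclobutyl on an aromatic nitrogen. With nothing measured for this change, the expected step from compound 1 to compound 3 is estimated as a 1.5-fold higher number from compound 1 to compound 3 (0.16 log units; within the scatter), that is, no move beyond the scatter is expected. The value of compound 3 in this assay is estimated at 0.09 h, within a range of 0.04 h to 0.25 h.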

Compound 3, half-life: 0.233 h
For compound 3 the middle estimate is 2.6-fold (0.41 log units) below the measured one; measured number inside the range.
By their numbers in this assay, from the lowest: compound 1; then compound 3; then compound 2.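

In this assay, the group on an aromatic nitrogen proves to be a place where ring size alone moves the number: cyclopropyl in place of cyclobutyl gives a 3.8-fold higher number from compound 1 to compound 3 (0.58 log units; beyond the scatter), with the rest of compound 1 unchanged. Among the compounds shown here, this is the first step that isolates a single place, as compound 1 and compound 2 differ in more than one, and it shows that the smaller carbon ring is the longer-lived of these two on the shared core. Nothing at hand accounts for the size or direction of this step, which remains a single pair.

On these data alone, open-chain isopropyl and the oxygen-containing oxetane ring on the same aromatic nitrogen remain open. As far as these compounds go, it is also open whether the step from cyclobutyl to cyclopropyl carries over when trifluoromethyl replaces the chlorine on the shared core.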